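Arylamino in place of azetidinyl on the shared core

The compounds below may be only part of what the source reports. "The series", "measured", "known", "first", "only" and "open" are said of these compounds alone.

Compound 1 `O=C1C=C(N2CCC2)C(=O)c2c1nc1n2[C@H]2OC[C@@H](O)[C@H]2OC1`: in a functional assay on ECa-109 cells for inhibition, with ECa-109 cell line (Homo sapiens) as the target, read by sulforhodamine B assay (a lower number here means a stronger inhibitor, a higher number a weaker inhibitor), compound 1 gives > 16000 nM, a limit of the assay.
Compound 2 `Cc1ccc(NC2=CC(=O)c3c(nc4n3[C@H]3OC[C@@H](O)[C@H]3OC4)C2=O)cc1`: in this assay compound 2 gives > 4000 nM, also a limit.
Compound 3 `Cc1ccc(NC2=CC(=O)c3c(nc4n3[C@H]3OC[C@@H](O)[C@H]3OC4)C2=O)cc1C`: in this assay compound 3 gives 4090 nM.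

Compound 1 stands only at a limit (the limit of > 16000 nM in this assay, at which 1 of the 3 values shown sits), and the shown values do not separate it from compound 2, which also sits at a limit (the limit of > 4000 nM in this assay, at which 1 of the 3 values shown sits). Compound 4 `COc1ccc(NC2=CC(=O)c3nc4n(c3C2=O)[C@H]2OC[C@@H](O)[C@H]2OC4)cc1` carries (4-methoxyphenyl)amino in place of azetidin-1-yl on a double-bonded ring carbon. For the measured compounds named here, the single measured step, a step that the limit leaves unreadable from compound 2 to compound 3, cannot be sized because compound 2 sits at a limit (the limit of > 4000 nM in this assay, at which 1 of the 3 values shown sits). Going by the values given here, no measured step bears directly on the change from compound 1 to compound 4; the two arylamino analogs, compounds 2 and 3, sit at or near the limits, so no move beyond the scatter can be read. Compound 4 is expected near compound 3, estimated at 6000 nM (range 2500 nM to 16000 nM), which means an expected step of an at least 2.6-fold lower number from compound 1 to compound 4 (0.42 log units; beyond the scatter).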

Compound 4, half-maximal inhibitory concentration: > 4000 nM
Compound 4: a limit, no number (the forecaster's own chance of this, stated with the estimate: 40%); the middle value lies beyond the limit too.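

The step from compound 1 to compound 4 cannot be read: both compounds stand at limits, not numbers. Going by these compounds, whether (4-methoxyphenyl)amino in place of azetidin-1-yl changes the inhibition at all, and in which direction, stays open.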